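The source may hold more compounds than are shown below. What is called first, only, known or untested is meant among the compounds shown, and "the series" means these compounds.

Working notes on the series. Going by the values given here, in a functional assay on HT-29 cells (Homo sapiens) for cytotoxicity, read by resazurin assay, with a stated time of 48 h (on this read-out lower numbers stand for an effect already at smaller amounts and higher numbers for an effect only at larger amounts of compound), compound 1 (`COc1ccc(S(=O)(=O)Nc2ccc(-c3nc4cc(NS(=O)(=O)c5ccc(OC)cc5)ccc4o3)cc2)cc1`) gives 40000 nM and compound 2 (`COc1ccc(S(=O)(=O)Nc2ccc3oc(-c4ccc(NC(=O)c5cccc(C)c5[N+](=O)[O-])cc4)nc3c2)cc1`) gives 2300 nM, so compound 2 holds the lower of the two numbers measured so far. Compound 3 (`COc1ccc(S(=O)(=O)Nc2ccc3oc(-c4ccc(NC(=O)c5ccc(Cl)s5)cc4)nc3c2)cc1`) is the next to be read. It carries 5-chlorothiophen-2-yl in place of 3-methyl-2-nitrophenyl on a carbonyl carbon.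

Among the compounds with values here, only one measured step bears on this change: a 17-fold lower number from compound 1 to compound 2 (1.24 log units; beyond the scatter). That step is large and beyond the scatter, and it shows that the number responds to a change on this nitrogen. However, it replaced a sulfonyl group with a carbonyl group, whereas here the carbonyl stays and only the group on it changes. Within the data shown here, no measured pair tests such an exchange alone, so the large step does not carry over and no direction can be assigned with confidence. In this assay, the expected step is a 1.1-fold higher number from compound 2 to compound 3 (0.04 log units; within the scatter), which is no change beyond the scatter. For compound 3, the estimated value is 2500 nM, with an expected range of 700 nM to 9000 nM.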

Compound 3, half-maximal effective concentration: 1900 nM
Estimate against measurement, compound 3: 1.3-fold (0.12 log units) above; the measured number falls inside the stated range.
By their numbers in this assay, from the lowest: compounds 3 and 2 (each within the scatter of the next); then compound 1.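

In this assay, going by these compounds alone, the change on the carbonyl carbon tests the group on the carbonyl alone for the first time, and a 1.2-fold lower number from compound 2 to compound 3 (0.08 log units; within the scatter) lies within the scatter. The two groups are therefore not told apart here, although 5-chlorothiophen-2-yl has a five-membered aromatic ring with 1 hetero atom and 6 heavy atoms, while 3-methyl-2-nitrophenyl has a six-membered aromatic ring of carbon only and 10 heavy atoms. The exchange on the nitrogen on an aromatic ring now has a second reading, a 21-fold lower number from compound 1 to compound 3 (1.32 log units; beyond the scatter) beside a 17-fold lower number from compound 1 to compound 2 (1.24 log units; beyond the scatter) for the earlier pair, so with two different groups on the carbonyl both steps are large and beyond the scatter, and neither compound goes against this.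

The compounds shown leave open whether the same holds for a much smaller group on the carbonyl, such as methyl, or for an amine or a carboxylic acid on the aromatic ring of the acyl group. No measurement at hand gives a cause for either step.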